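A few compounds are considered here, and "the series" means these few. Any claim that something is new, unique, unknown or untested is made for them only; others in the source may bear on it.

Compound 1 `NC(=O)C1CCN(C(=O)c2c[nH]c3ccccc23)CC1` is measured in an ADME assay for permeability, using PAMPA, at pH 7.4 (on this read-out lower numbers stand for lower permeability and higher numbers for higher permeability), only as a limit, < 0.01 10^-6 cm/s, so its position on the numbers is not fixed; it sits at the limit of < 0.01 10^-6 cm/s in this assay, at which 1 of the 2 values shown sits. Compound 2 `COC(=O)c1ccc2ccc(C(=O)N(C)C)c-2cc1` gives 7.4 10^-6 cm/s in this assay. Compound 3 `Cn1cc(C(=O)N2CCC(C(N)=O)CC2)c2ccccc21` differs from compound 1 by methyl in place of hydrogen on an aromatic nitrogen. Among the measured compounds shown here, no measured step covers this change, so its effect rests on expectation alone: an increase beyond the scatter is expected, of the size an at least 10-fold higher number from compound 1 to compound 3 (1.00 log units; beyond the scatter). Compound 3 is estimated at 0.1 10^-6 cm/s in this assay, within 0.01 10^-6 cm/s to 1 10^-6 cm/s, with a real chance of another limit.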

Compound 3, apparent permeability in the ADME assay: 0.2 10^-6 cm/s
Compound 3: the middle estimate sits 2.0-fold (0.30 log units) below what was measured; the range from low to high includes it.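

Among the compounds shown here, in the ADME assay, methyl in place of hydrogen on the aromatic nitrogen is the first measured change at this position and gives an at least 20-fold higher number from compound 1 to compound 3 (1.30 log units; beyond the scatter). The value of compound 1 in this read-out is a limit, so the step fixes only a lower bound. In a physicochemical assay for lipophilicity, read by HPLC, measured as octanol-water partition, at pH 11 (a lower number here means a more polar compound, a higher number a more lipophilic compound), compound 1 gives -0.2 and compound 3 gives 0.4, which is a number 0.60 log units higher from compound 1 to compound 3 (beyond the scatter).

As far as these compounds go, whether a longer chain or a carboxylic acid on this aromatic nitrogen would shift either read-out further remains open. From the compounds shown here alone, with a single pair, the link between the two shifts also remains open.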